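Furan-2-yl for phenyl: a second instance in the series

The compounds below may be only part of what the source reports. "The series", "measured", "known", "first", "only" and "open" are said of these compounds alone.

In a functional assay on DU-145 cells (Homo sapiens) for cytotoxicity, read by CCK-8 assay and cell counting, with a stated time of 2 days (on this read-out lower numbers stand for stronger inhibition and higher numbers for weaker inhibition), compound 1 `Oc1ccc(-c2cc(-c3ccccc3)nc(-c3ccccc3Cl)c2)cc1` gives 2800 nM. Compound 2 `Oc1ccc(-c2cc(-c3ccco3)nc(-c3ccccc3Cl)c2)cc1` carries the change furan-2-yl in place of phenyl on an aromatic carbon and in this assay compound 2 gives 5300 nM, so that a 1.9-fold higher number from compound 1 to compound 2 (0.28 log units; within the scatter). Compound 3 `Oc1cccc(-c2cc(-c3ccccc3)nc(-c3ccc(Cl)cc3)c2)c1` has the same atoms as compound 1 joined differently; the difference between the two cores is not broken down here. In this assay compound 3 gives 11200 nM, the highest number of the three and beyond the scatter from both compound 1 and compound 2. Compound 4 `Oc1cccc(-c2cc(-c3ccc(Cl)cc3)nc(-c3ccco3)c2)c1` is not yet measured and differs from compound 3 by furan-2-yl in place of phenyl on an aromatic carbon. This is the same kind of change as the earlier one, not the same: earlier the place was meta to a 2-chlorophenyl group and to a 4-hydroxyphenyl group, here it is meta to a 4-chlorophenyl group and to a 3-hydroxyphenyl group. Among the measured compounds shown here, for compound 4 the expected step is a 1.7-fold higher number from compound 3 to compound 4 (0.23 log units; within the scatter), resting on the single earlier instance a 1.9-fold higher number from compound 1 to compound 2 (0.28 log units; within the scatter) and on compound 3 already standing at 11200 nM. Compound 4 is therefore estimated at 19000 nM, expected between 8000 nM and 45000 nM.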

Compound 4, half-maximal inhibitory concentration: 11400 nM
Compound 4: the middle estimate sits 1.7-fold (0.22 log units) above what was measured; low and high end bracket the measured number.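

In this assay, furan-2-yl in place of phenyl on the core of compound 3 gives a 1.0-fold higher number from compound 3 to compound 4 (0.01 log units; within the scatter), so this second instance also stays within the scatter. The two instances do not differ, and in this series the change carries from one core to the other with no step beyond the scatter on either: the same change on two cores in this assay, a 1.9-fold higher number (0.28 log units; within the scatter) from compound 1 to compound 2 and a 1.0-fold higher number (0.01 log units; within the scatter) from compound 3 to compound 4, 1.9-fold (0.27 log units) apart, within the scatter of two such steps. Among the compounds shown here, this rests on only two pairs and does not show that the swap would behave alike on any further core, nor does it say what part the 2-chlorophenyl or 4-chlorophenyl group and the 4-hydroxyphenyl or 3-hydroxyphenyl group play in the outcome.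

The compounds shown carry only phenyl or furan-2-yl at this place, so the effect of an amine, a carboxylic acid or a longer chain there remains open. Also open, from the compounds shown here alone, is whether the same picture would hold with a methoxy group in place of the hydroxyl on the hydroxyphenyl ring.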